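Methyl added to the glycine chain of a nitrophenyl oxadiazole

This account rests on a few compounds, and the source may have more. Where it says the series, first, only, none or still open, it means among the compounds named here.

Measured so far:
compound 1, `C[C@@H](N)C(=O)NCc1nnc(-c2ccccc2)o1`: 98 nM
compound 2, `NCC(=O)NCc1nnc(-c2ccc([N+](=O)[O-])cc2)o1`: 134 nM

In an assay for inhibition of histone deacetylase 8 (Homo sapiens), read by fluorescence, with a stated time of 15 min (a lower number here means a stronger inhibitor, a higher number a weaker inhibitor), compound 1 gives 98 nM and compound 2 gives 134 nM; the gap between compound 2 and compound 1 is within the scatter, so neither stands apart from the other. Compound 3, `C[C@@H](N)C(=O)NCc1nnc(-c2ccc([N+](=O)[O-])cc2)o1`, carries the change (methyl in place of hydrogen on a saturated chain carbon bound to an amine nitrogen and a carbonyl carbon), methyl in place of hydrogen on a saturated chain carbon bound to an amine nitrogen and a carbonyl carbon. Among the compounds with values here, no measured pair shows this step alone, and compound 1 already holds the methyl with a different aryl group. The step from compound 2 to compound 3 is expected to be small, a 1.3-fold lower number from compound 2 to compound 3 (0.13 log units; within the scatter), not clearly beyond the scatter. Compound 3 is estimated at 100 nM, between 45 nM and 220 nM.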

Compound 3, half-maximal inhibitory concentration: 127 nM
The estimate for compound 3 lay 1.3-fold (0.10 log units) below the measured number; the measured number falls inside the stated range.
By their numbers in this assay, from the lowest: compounds 1, 3 and 2 (each within the scatter of the next).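

In this assay, methyl in place of hydrogen on the saturated chain carbon bound to an amine nitrogen and a carbonyl carbon gives no readable change: a 1.1-fold lower number from compound 2 to compound 3 (0.02 log units; within the scatter). With that methyl present, nitro in place of hydrogen on an aromatic carbon also stays within the scatter: a 1.3-fold higher number from compound 1 to compound 3 (0.11 log units; within the scatter). No supporting data on the reason for either result accompany the series.

Still open, from the compounds shown here alone, is whether an ethyl group or a longer chain on that carbon would behave like methyl. The compounds also leave open how a methoxy group or a chlorine would compare with nitro on the aromatic carbon.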